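Swapping nitro for amino on a compound at the limit

The compounds below may be only part of what the source reports. "The series", "measured", "known", "first", "only" and "open" are said of these compounds alone.

In a functional assay on SGC-7901 cells (Homo sapiens) for antiproliferative activity, read by MTT assay, with a stated time of 72 h (a lower number here means a stronger inhibitor, a higher number a weaker inhibitor), compound 1 (`COc1ccc(-c2c(-c3cc(OC)c(OC)c(OC)c3)ss/c2=N/O)cc1[N+](=O)[O-]`) gives 6560 nM and compound 2 (`COc1ccc(-c2c(-c3cc(OC)c(OC)c(OC)c3)ss/c2=N/O)cc1N`) gives 2910 nM as its read-out. Compound 3 (`CO/N=c1/ssc(-c2cc(OC)c(OC)c(OC)c2)c1-c1ccc(OC)c([N+](=O)[O-])c1`) gives > 100000 nM as a limit of the assay and not a number. Compound 4 (`CO/N=c1/ssc(-c2cc(OC)c(OC)c(OC)c2)c1-c1ccc(OC)c(N)c1`) differs from compound 3 by amino in place of nitro on an aromatic carbon. The same swap gave a 2.3-fold lower number from compound 1 to compound 2 (0.35 log units; beyond the scatter) as a modest step. Methyl in place of hydrogen on an oxygen gave an at least 15-fold higher number from compound 1 to compound 3 (1.18 log units; beyond the scatter) as a large step, and compound 4 keeps that methyl. A modest lowering is therefore expected in this assay with an at least 2.0-fold lower number from compound 3 to compound 4 (0.30 log units; that floor lies within the scatter) as the estimated step. Compound 4 is expected at 50000 nM with an estimated range from 12000 nM to 100000 nM. A limit of the assay remains possible for compound 4.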

Compound 4, half-maximal inhibitory concentration: 1960 nM
Compound 4: middle estimate off by 26-fold (1.41 log units), on the high side; measured number outside the range, below it.
By their numbers in this assay, from the lowest: compounds 4 and 2 (each within the scatter of the next); then compound 1. At a limit, above all of these: compound 3.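

In this assay compound 3 gives > 100000 nM, a limit of the assay and not a number. Amino in place of nitro on this aromatic carbon gives an at least 51-fold lower number from compound 3 to compound 4 (1.70 log units; beyond the scatter), so the size of this swap depends on the core: the same change on two cores in this assay, a 2.3-fold lower number (0.35 log units; beyond the scatter) from compound 1 to compound 2 and an at least 51-fold lower number (1.70 log units; beyond the scatter) from compound 3 to compound 4, at least 22-fold (1.35 log units) apart, beyond the scatter of two such steps. With amino on the ring, methyl in place of hydrogen on the oxygen gives only a 1.5-fold lower number from compound 2 to compound 4 (0.17 log units; within the scatter), unlike its step with nitro on the ring: the same change on two cores in this assay, an at least 15-fold higher number (1.18 log units; beyond the scatter) from compound 1 to compound 3 and a 1.5-fold lower number (0.17 log units; within the scatter) from compound 2 to compound 4, at least 22-fold (1.35 log units) apart, beyond the scatter of two such steps.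

Still open, going by these compounds, is whether a carboxylic acid or a dimethylamino group at this position would match amino, and whether an ethyl group on that oxygen would match methyl.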